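Ester-to-acid change on a quinoline styryl ether

The compounds below may be only part of what the source reports. "The series", "measured", "known", "first", "only" and "open" are said of these compounds alone.

Of the compounds shown here, three have been measured in a functional assay on lung (Cavia porcellus) for binding affinity to cysteinyl leukotriene receptor (Homo sapiens); a higher number here means a weaker inhibitor, a lower number a stronger inhibitor. Compound 1 `C/C(=C/c1ccc2ccc(Cl)cc2n1)c1cccc(OC(C)C(=O)O)c1` gives 495 nM, compound 2 `CCCCSc1ccc2ccc(/C=C/c3cccc(OCC(=O)OC)c3)nc2c1` gives 1500 nM, and compound 3 `COC(=O)COc1cccc(/C=C/c2ccc3ccccc3n2)c1` gives 1000 nM. The step of a 1.5-fold lower number from compound 2 to compound 3 (0.18 log units; within the scatter) is within the scatter. Compound 3 therefore stands second highest of the three, with compound 2 nearest and compound 1 furthest, the latter gap being beyond the scatter. Compound 4 `O=C(O)CCCOc1cccc(/C=C/c2ccc3ccccc3n2)c1` differs from compound 3 by 2-carboxyethyl in place of methoxycarbonyl on a saturated chain carbon bound to an oxygen on an aromatic ring. For the measured compounds named here, no measured step concerns this change; the only computed step, from compound 2 to compound 3, alters a different part of the molecule. Compound 4 is expected to give 500 nM, with a range from 150 nM to 1600 nM. The expected step is a 2.0-fold lower number from compound 3 to compound 4 (0.30 log units; within the scatter), a modestly lower number.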

Compound 4, half-maximal inhibitory concentration: 480 nM
For compound 4 the middle estimate is 1.0-fold (0.02 log units) above the measured one; low and high end bracket the measured number.
By their numbers in this assay, from the lowest: compounds 4 and 1 (each within the scatter of the next); then compounds 3 and 2 (each within the scatter of the next).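

In this assay, for the compounds shown here, putting 2-carboxyethyl in place of methoxycarbonyl on a saturated chain carbon bound to an oxygen on an aromatic ring gives a 2.1-fold lower number from compound 3 to compound 4 (0.32 log units; beyond the scatter) and is the first step at this position, a modest one beyond the scatter. That single step turns the ester into a carboxylic acid and lengthens the chain together, so the two changes cannot be separated. No evidence here bears on this result.

Going by these compounds, whether the carboxylic acid alone or the longer chain alone would give the same number stays open, as could be read from (carboxy)methyl or a 3-(methoxycarbonyl)propyl group. On these data alone, how an amine in place of the carboxylic acid would compare also remains open.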